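Swapping the Pyrazole Substituent on a Weak Antiproliferative Core

This account rests on a few compounds, and the source may have more. Where it says the series, first, only, none or still open, it means among the compounds named here.

Of the compounds shown here, two have been tested in a functional assay on MDA-MB-453 cells (Homo sapiens) for antiproliferative activity, read by MTT assay, with a stated time of 72 h; a lower number here means a stronger inhibitor, a higher number a weaker inhibitor. Compound 1 `O=C1NN=C(c2ccccc2)/C1=C/Nc1cc(-c2ccco2)[nH]n1` gives 20900 nM. Compound 2 `CCOC(=O)c1c[nH]nc1N/C=C1\C(=O)N(c2ccccc2)N=C1c1ccccc1` gives 19400 nM; this is the lowest of the two numbers, yet compound 1 sits within the scatter of it, so the pair cannot be told apart. Compound 3 `O=C1/C(=C\Nc2cc(-c3ccco3)[nH]n2)C(c2ccccc2)=NN1c1ccccc1` has not yet been measured. It differs from compound 2 in one place: 5-(furan-2-yl)-1H-pyrazol-3-yl in place of 4-(ethoxycarbonyl)-1H-pyrazol-3-yl on an amine nitrogen. Within the data shown here, no pair of measured compounds covers exactly this exchange, so the expectation rests on the two numbers at hand. Compound 1 carries the group that enters, and its value is close to that of compound 2. The step is therefore expected to be small, a 1.0-fold higher number from compound 2 to compound 3 (0.01 log units; within the scatter), with no direction beyond the scatter. Compound 3 is estimated at 20000 nM, with a range from 8000 nM to 50000 nM.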

Compound 3, half-maximal inhibitory concentration: 12400 nM
Compound 3: middle estimate off by 1.6-fold (0.21 log units), on the high side, within the range that was stated.
By their numbers in this assay, from the lowest: compounds 3, 2 and 1 (each within the scatter of the next).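

In this assay, 5-(furan-2-yl)-1H-pyrazol-3-yl in place of 4-(ethoxycarbonyl)-1H-pyrazol-3-yl on an amine nitrogen gives a 1.6-fold lower number from compound 2 to compound 3 (0.19 log units; within the scatter), so these two groups cannot be told apart at this position. A second exchange can now be read as well: phenyl in place of hydrogen on an amide-type nitrogen in a ring gives a 1.7-fold lower number from compound 1 to compound 3 (0.23 log units; within the scatter), and this change is not separated from the scatter either. No independent measurement bears on these results.

The compounds shown leave open whether any group at either place can produce a step beyond the scatter, for example a carboxylic acid in place of the ethoxycarbonyl group or a benzyl group in place of that phenyl. With three compounds, all within the scatter of each other, no order or pattern can be drawn.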